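This account rests on a few compounds, and the source may have more. Where it says the series, first, only, none or still open, it means among the compounds named here.

Measured compounds in a functional assay on KBVIN cells (Homo sapiens) for antiproliferative activity, read by sulforhodamine B assay, with a stated time of 3 days; a higher number here means that more compound is needed for the effect, a lower number that less compound is needed:
compound 1 `CCC1=C(O)c2c(oc(-c3ccc(SC)cc3)cc2=O)C(CC)(CC)C1=O`: 1.38 uM
compound 2 `CCC1=C(O)c2c(oc(-c3cc(OC)c(OC)c(OC)c3)cc2=O)C(CC)(CC)C1=O`: 5.6 uM
compound 3 `CCC1=C(O)c2c(oc(-c3cc(Cl)c(OC)c(OC)c3)cc2=O)C(CC)(CC)C1=O`: 8.4 uM

Compound 1 holds the lowest number of the three; compound 2 stands nearest to it, and compound 3 furthest, both gaps beyond the scatter. Going by the values given here, the only single-point step among the measured compounds is a 1.5-fold higher number from compound 2 to compound 3 (0.18 log units; within the scatter), which lies within the scatter.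

Compound 4 `CCC1=C(O)c2c(oc(-c3ccc(O)c(C)c3C)cc2=O)C(CC)(CC)C1=O` has not yet been measured in this assay. It differs from compound 1 by 4-hydroxy-2,3-dimethylphenyl in place of 4-(methylsulfanyl)phenyl on an aromatic carbon.

Among the compounds with values here, none of the measured steps bears directly on this change: the step from compound 2 to compound 3 swaps a methoxy for a chloro and says nothing about a hydroxy group or about methyl groups on the aryl ring. What the numbers do show is that compound 1, with 4-(methylsulfanyl)phenyl, gives a lower number than compounds 2 and 3, which carry more heavily substituted aryl rings. On that thin basis a moderate rise is expected for compound 4, with a 2.2-fold higher number from compound 1 to compound 4 (0.34 log units; beyond the scatter). The value of compound 4 in this assay is estimated at 3 uM, with a range from 1 uM to 10 uM.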

Compound 4, concentration for half-maximal effect: 2.75 uM
For compound 4 the middle estimate is 1.1-fold (0.04 log units) above the measured one, within the range that was stated.
By their numbers in this assay, from the lowest: compounds 1 and 4 (each within the scatter of the next); then compounds 2 and 3 (each within the scatter of the next).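

In this assay, 4-hydroxy-2,3-dimethylphenyl in place of 4-(methylsulfanyl)phenyl on the aromatic carbon next to the ring oxygen gives a 2.0-fold higher number from compound 1 to compound 4 (0.30 log units; within the scatter), the only step shown that replaces the whole aryl group at this place, whereas the earlier step exchanged one substituent on a ring that otherwise stayed the same. Compound 4 carries no sulfur and counts a hydrogen-bond donor where the group of compound 1 counts none, yet the two compounds stay within the scatter of each other, so the low number of compound 1 is not tied to 4-(methylsulfanyl)phenyl alone. Nothing available explains why two such different groups give numbers this close.

The compounds shown do not separate the contribution of the hydroxy group from that of the methyl groups, since all of them enter together in a single step. They also leave open whether an unsubstituted phenyl, or an aryl group carrying an amine or a carboxylic acid, would stay within the scatter of compound 1 at this place.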